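The compounds below may be only part of what the source reports. "The series", "measured", "known", "first", "only" and "open" are said of these compounds alone.

Three compounds have been measured in a functional assay on HeLa cells (Homo sapiens) for cytotoxicity, read by MTT assay; on this read-out higher numbers stand for weaker inhibition and lower numbers for stronger inhibition:

Compound 1, `Cc1oc2c3c(ccc2c(=O)c1C)OC[C@H]1[C@@H]3c2c(ccc(C(=O)Cc3ccccc3)c2O)OC1(C)C`, gives > 100000 nM, a limit of the assay.
Compound 2, `Cc1coc2c3c(ccc2c1=O)OC[C@H]1[C@@H]3c2c(ccc(C(=O)Cc3ccccc3)c2O)OC1(C)C`, gives > 100000 nM, again a limit.
Compound 3, `Cc1oc2c3c(ccc2c(=O)c1C)OC[C@H]1[C@@H]3c2ccc3ccccc3c2OC1(C)C`, gives > 100000 nM, also a limit.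

The change from compound 1 to compound 2, (hydrogen in place of methyl on an aromatic carbon), yields a step that the two limits leave unreadable from compound 1 to compound 2, since both values sit at the limit of > 100000 nM in this assay, at which 3 of the 3 values shown sit. The difference between the cores of compound 1 and compound 3 is not broken down here. Compound 4, `Cc1coc2c3c(ccc2c1=O)OC[C@H]1[C@@H]3c2ccc3ccccc3c2OC1(C)C`, arises from compound 3 by the same kind of change, (hydrogen in place of methyl on an aromatic carbon); the place differs only in that the ring is part of a fused or bridged system of six rings rather than five. Given that compound 3 gives > 100000 nM and the earlier step was unreadable, compound 4 is expected to show a step that the limit leaves unreadable from compound 3 to compound 4. Compound 4 is estimated at 200000 nM, most likely reported once more as a limit.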

Compound 4, half-maximal inhibitory concentration: > 100000 nM
Compound 4: only a limit was reported; the forecaster's own chance of this, stated with the estimate: 85%; the middle value lies beyond the limit too.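

No step from compound 3 to compound 4 can be read, as both values are limits: the limit of > 100000 nM in this assay, at which 4 of the 4 values shown sit.

The compounds shown leave open whether hydrogen in place of methyl on an aromatic carbon changes anything in this assay, and which structure would give a value inside its range.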